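A few compounds are considered here, and "the series" means these few. Any claim that something is new, unique, unknown or untested is made for them only; others in the source may bear on it.

Compound 1 `Cc1ccc(-c2cc(/N=C3/NC(=O)CS3)cs2)cc1`, in a functional assay on MCF7 cells (Homo sapiens) for cytotoxicity, read by MTT assay, with a stated time of 72 h; a lower number here means a stronger inhibitor, a higher number a weaker inhibitor: > 50000 nM
Compound 2 `COc1cccc(N2C(=O)CS/C2=N\c2csc(-c3ccccc3)c2)c1`, in this assay: "not determined" (no result reported)

The value of compound 1 in this assay is a limit of the assay, not a number (the limit of > 50000 nM in this assay, at which 1 of the 2 values shown sits). For compound 2 no result in this assay was reported, so compound 2 stands nowhere on the numbers shown. Compound 3 `COc1cccc(N2C(=O)CS/C2=N\c2csc(-c3ccc(C)cc3)c2)c1` differs from compound 2 by methyl in place of hydrogen on an aromatic carbon. Among the measured compounds shown here, no step between measured compounds exists, so the size of this change cannot be read from the data; a shift in this assay no larger than the usual scatter, in either direction, is expected. Compound 3 is expected to give about 40000 nM in this assay, between 8000 nM and 100000 nM, with a fair chance that only a limit is returned.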

Compound 3, half-maximal inhibitory concentration: > 50000 nM
Compound 3: no number, only a limit (the forecaster's own chance of this, stated with the estimate: 60%); at least 1.2-fold (0.09 log units) between middle value and limit.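

Compound 1 and compound 3 each give only a limit of the assay in this assay and no number, and the step between them cannot be read. The compounds shown leave open what phenyl to 4-methylphenyl does, as compound 2 has no reported result.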